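The compounds below may be only part of what the source reports. "The series", "measured", "known", "first", "only" and "open" are said of these compounds alone.

Compound 1 `C=CC(=O)NCCOc1ccc(Oc2c(-c3ccc(F)cc3)sc3cc(O)ccc23)cc1`: > 25000 nM
Compound 2 `C=C(C)C(=O)NCCOc1ccc(Oc2c(-c3ccc(F)cc3)sc3cc(O)ccc23)cc1`: > 25000 nM
Compound 3 `O=C(/C=C/CNCCOc1ccc(Oc2c(-c3ccc(F)cc3)sc3cc(O)ccc23)cc1)N1CCC1`: 6560 nM

In a functional assay on Ishikawa cells (Homo sapiens) for antiproliferative activity, read by CCK-8 assay, with a stated time of 48 h (on this read-out lower numbers stand for stronger inhibition and higher numbers for weaker inhibition), compound 1 reaches only a limit, > 25000 nM. Compound 2 likewise stops at a limit, > 25000 nM, so the step that the two limits leave unreadable from compound 1 to compound 2 cannot be read; both sit at the limit of > 25000 nM in this assay, at which 2 of the 3 values shown sit. Among the compounds with values here, compound 3 gives a number, 6560 nM, and the step of an at least 3.8-fold lower number from compound 1 to compound 3 (0.58 log units; beyond the scatter) is the one readable change in the set, matched by an at least 3.8-fold lower number from compound 2 to compound 3 (0.58 log units; beyond the scatter).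

Compound 4 `CN(C)C(=O)/C=C/CN1CC(Oc2ccc(Oc3c(-c4ccc(F)cc4)sc4cc(O)ccc34)cc2)C1` is not yet measured. Its change from compound 1 is 1-(3-(dimethylcarbamoyl)prop-2-en-1-yl)azetidin-3-yl in place of 2-((vinylcarbonyl)amino)ethyl on an oxygen on an aromatic ring. As in compound 3, the carbonyl is moved away from the nitrogen onto a chain ending in an amide, and the nitrogen becomes part of a four-membered ring. Within the data shown here, the only step that bears on it is an at least 3.8-fold lower number from compound 1 to compound 3 (0.58 log units; beyond the scatter), which was at least modest and downward; the step of compound 4 is therefore expected in the same direction, an at least 5.0-fold lower number from compound 1 to compound 4 (0.69 log units; beyond the scatter). Compound 4 is estimated at 5000 nM, within 1500 nM to 16000 nM.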

Compound 4, half-maximal inhibitory concentration: 11200 nM
Compound 4: middle estimate off by 2.2-fold (0.35 log units), on the low side; the measured number falls inside the stated range.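

In this assay, within the data shown here, compound 3 is no longer the only compound to give a number: with 1-(3-(dimethylcarbamoyl)prop-2-en-1-yl)azetidin-3-yl on the oxygen on an aromatic ring, there is an at least 2.2-fold lower number from compound 1 to compound 4 (0.34 log units; beyond the scatter), and likewise an at least 2.2-fold lower number from compound 2 to compound 4 (0.34 log units; beyond the scatter). Both steps are bounded on one side only, since compound 1 and compound 2 each stop at a limit rather than a number: the limit of > 25000 nM in this assay, at which 2 of the 4 values shown sit. Against compound 3 there is a 1.7-fold higher number from compound 3 to compound 4 (0.23 log units; within the scatter), so these two amine-bearing side chains cannot be told apart here.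

The compounds shown leave open which part of the side chain of compound 4 matters, the four-membered ring or the dimethylcarbamoyl end, as the two arrive together. They also leave open how a piperidine in place of the azetidine, or a longer chain before the amine nitrogen, would fare in this assay.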